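Swapping one aromatic ring in a fast-cleared compound

The source may hold more compounds than are shown below. What is called first, only, known or untested is meant among the compounds shown, and "the series" means these compounds.

In an in vitro ADME assay on microsomes from liver (Homo sapiens) for metabolic stability (on this read-out higher numbers stand for fast clearance and lower numbers for slow clearance), compound 1 (`O=C(COCc1ccncc1)N1CCN(c2ccc(F)cc2F)CC1`) gives 22 mL.min-1.g-1 and compound 2 (`O=C(COCc1ccccn1)N1CCN(c2ccc(Cl)cc2Cl)CC1`) gives 94 mL.min-1.g-1 as the higher of the two numbers, a gap beyond the usual scatter. Compound 3 (`O=C(COCc1nccs1)N1CCN(c2ccc(Cl)cc2Cl)CC1`) carries 1,3-thiazol-2-yl in place of pyridin-2-yl on a saturated chain carbon bound to an oxygen on a saturated carbon. Going by the values given here, no measured pair shows this swap, so the change expected in this assay is only a slight fall (a 1.3-fold lower number from compound 2 to compound 3 (0.13 log units; within the scatter)) that stays within the scatter. For compound 3 the estimate is 70 mL.min-1.g-1 with 35 mL.min-1.g-1 to 140 mL.min-1.g-1 as its expected range.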

Compound 3, intrinsic clearance in microsomes: 80 mL.min-1.g-1
Compound 3: the middle estimate sits 1.1-fold (0.06 log units) below what was measured; measured number inside the range.
By their numbers in this assay, from the lowest: compound 1; then compounds 3 and 2 (each within the scatter of the next).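

In this assay, setting 1,3-thiazol-2-yl in place of pyridin-2-yl on a saturated chain carbon bound to an oxygen on a saturated carbon gives a 1.2-fold lower number from compound 2 to compound 3 (0.07 log units; within the scatter). Going by these compounds alone, this is the first pair differing in one place, and it shows that this five-membered ring and this six-membered ring cannot be told apart here. No measurement at hand accounts for this result.

On these data alone, whether a plain phenyl ring or an amine at this place would move the number stays open. So does whether this swap would read the same with the rest of compound 1.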